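Moving the chlorine on the benzylsulfanyl arm of compound 2

A few compounds are considered here, and "the series" means these few. Any claim that something is new, unique, unknown or untested is made for them only; others in the source may bear on it.

Measured compounds:
compound 1 `CC1=C(C(=O)Nc2ccc(Br)cc2)C(c2ccc(Cl)cc2Cl)N=C(SCc2cccc(Cl)c2)N1`: 8.8%
compound 2 `COc1ccc(C2N=C(SCc3ccccc3Cl)NC(C)=C2C(=O)Nc2ccc(Br)cc2)cc1`: 8.2%

Of the compounds shown here, two have been tested in a functional assay on the whole organism (artery, strain albino) with Rattus norvegicus as the target, with a stated time of 120 min, at a dose of 10 mg/kg by the oral route (a higher number here means more inhibition at the dose given (going by the name of the read-out), a lower number less inhibition), and both sit low. In this assay compound 1 gives 8.8%, and compound 2 gives 8.2%; the two numbers lie within the usual scatter of each other, so compound 2 stands side by side with compound 1 rather than apart from it.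

Compound 3 `COc1ccc(C2N=C(SCc3cccc(Cl)c3)NC(C)=C2C(=O)Nc2ccc(Br)cc2)cc1` is the third member and has not yet been measured. It differs from compound 2 in one place: 3-chlorophenyl in place of 2-chlorophenyl on a saturated chain carbon bound to a sulfur. Among the measured compounds shown here, no pair of measured compounds is joined by a single such change, so there is no measured step to lean on. What the data do offer is compound 1, which already carries the (3-chlorobenzyl)sulfanyl group and gives 8.8% in this assay, a value that does not stand apart from compound 2.

The step from compound 2 to compound 3 is therefore expected to be small, a number 0.8 percentage points higher from compound 2 to compound 3 (within the scatter), with no change beyond the scatter in either direction. Compound 3 is estimated to give 9% in this assay, in the range 0% to 22%.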

Compound 3, a percentage reported as inhibition, in the whole organism at one dose (the size of the read-out at that dose, not a potency): 21.1%
Estimate against measurement, compound 3: 12.1 percentage points below; the range from low to high includes it.
By their numbers in this assay, from the lowest: compounds 2 and 1 (each within the scatter of the next); then compound 3.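

Moving the chlorine on this arm, with 3-chlorophenyl in place of 2-chlorophenyl on a saturated chain carbon bound to a sulfur, gives the first single change in this assay that can be read, and it yields a number 12.9 percentage points higher from compound 2 to compound 3 (beyond the scatter). With the (3-chlorobenzyl)sulfanyl arm held fixed, 4-methoxyphenyl in place of 2,4-dichlorophenyl on a saturated ring carbon also counts, giving a number 12.3 percentage points higher from compound 1 to compound 3 (beyond the scatter); compound 1 and compound 2 differ in two places, so their close values could not show that either place mattered on its own. Nothing given here bears on why these two changes act as they do.

The compounds shown leave open whether the number depends on a chlorine at all on this arm, and how plain benzyl or 4-chlorobenzyl on the sulfur would compare with the (3-chlorobenzyl)sulfanyl arm. As far as these compounds go, it also remains open whether the same move of the chlorine would have a similar effect with 2,4-dichlorophenyl on the saturated ring carbon, since only the 4-methoxyphenyl compounds hold both arms.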